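Piperidine Substituent Exchange on a Dichlorophenyl Oxazolidine Core

A few compounds are considered here, and "the series" means these few. Any claim that something is new, unique, unknown or untested is made for them only; others in the source may bear on it.

Of the compounds shown here, two built on one shared core have been measured. Compound 1 `COc1cc(C(=O)N2CO[C@](CCN3CCC(n4c(O)nc5ccccc54)CC3)(c3ccc(Cl)c(Cl)c3)C2)cc(OC)c1OC` carries a 2-hydroxy-1H-benzimidazol-1-yl group on a saturated ring carbon of the six-membered non-aromatic ring with one nitrogen. In an assay on isolated protein for inhibition of Substance-P receptor (Cavia porcellus), tested at 1 ug/mL (a higher number here means more inhibition at the concentration tested (going by the name of the read-out), a lower number less inhibition), compound 1 gives 100%. Compound 2 `COc1cc(C(=O)N2CO[C@](CCN3CCN(c4ncccn4)CC3)(c3ccc(Cl)c(Cl)c3)C2)cc(OC)c1OC` replaces that ring system with a pyrimidinyl piperazine; in this assay compound 2 gives 100%. Compound 1 therefore stands level with compound 2 at the digits reported, the two values lying within the scatter of each other, so no order between them can be stated.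

The account now turns to compound 3 `COc1cc(C(=O)N2CO[C@](CCN3CCC(C(=O)c4ccc(Cl)cc4)CC3)(c3ccc(Cl)c(Cl)c3)C2)cc(OC)c1OC`, which has not yet been measured. It differs from compound 1 in one place: (4-chlorophenyl)carbonyl in place of 2-hydroxy-1H-benzimidazol-1-yl on a saturated ring carbon. The group that leaves brings one hydrogen-bond donor and three acceptors; the (4-chlorophenyl)carbonyl group that enters brings no donor and one acceptor, with one double bond outside aromatic rings.

Going by the values given here, no measured step guides this exchange. Given that compound 1 gives 100% and compound 2 gives 100% in this assay, a modest downward step is expected for compound 3, estimated at a number 12 percentage points lower from compound 1 to compound 3 (beyond the scatter). Compound 3 is expected to give about 88%, with a range from 55% to 100%.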

Compound 3, a percentage reported as inhibition, at one concentration (the size of the read-out at that concentration, not a potency): 97%
Compound 3: the middle estimate sits 9 percentage points below what was measured; the measured number falls inside the stated range.
By their numbers in this assay, from the lowest: compounds 3, 1 and 2 (each within the scatter of the next).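

In this assay, a number 3 percentage points lower from compound 1 to compound 3 (within the scatter) when (4-chlorophenyl)carbonyl takes the place of 2-hydroxy-1H-benzimidazol-1-yl on a saturated ring carbon, a step that lies within the scatter. At this position of the six-membered non-aromatic ring with one nitrogen, the loss of the only hydrogen-bond donor of the leaving group and of its five-membered aromatic ring, as well as the arrival of a chlorine-bearing benzene ring joined through a carbonyl, therefore leaves the number level, with no change that this read-out can separate from scatter. Nothing at hand explains this result or connects it to a measured property of either group.

The compounds shown leave open whether this saturated ring carbon would accept a much smaller group, such as a primary amine or a carboxylic acid, or a longer chain of plain carbon atoms, and whether the inhibition would then hold. They also leave open how compound 1 and compound 3 would compare in potency, as a read-out at one concentration gives no potency, and compound 3 at 97% stands close to the full scale of the read-out.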